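Swapping the anilide aryl for cyclopentyl: clearance outlook

The source may report more compounds than this note shows. Statements on the series, on what has been measured and on what is new or still open speak of the compounds shown alone.

Measured compounds:
compound 1, `CC(C)c1ccc(NC(=O)[C@H]2CN(C)C[C@@H]2c2ccc(/C=C/C(=O)Nc3ccccc3N)cc2)cc1`, 10 mL/min/kg
compound 2, `CN1C[C@H](C(=O)Nc2cccc(Cl)c2)[C@@H](c2ccc(/C=C/C(=O)Nc3ccccc3N)cc2)C1`, 7 mL/min/kg
compound 3, `CN1C[C@H](C(=O)Nc2ccc(F)c(Br)c2)[C@@H](c2ccc(/C=C/C(=O)Nc3ccccc3N)cc2)C1`, 15 mL/min/kg

In an in vitro ADME assay on microsomes from liver (Homo sapiens) for pharmacokinetics, read by LC-MS, with a stated time of 10 min, tested at 1 uM (a higher number here means faster removal of the compound, a lower number slower removal), compound 2 sits at the low end of the three numbers. Its separation from compound 1 is a 1.4-fold lower number from compound 1 to compound 2 (0.15 log units; within the scatter), whereas compound 3 stands apart from it by a 2.1-fold higher number from compound 2 to compound 3 (0.33 log units; beyond the scatter); compound 1 and compound 3 differ by a 1.5-fold higher number from compound 1 to compound 3 (0.18 log units; within the scatter).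

Compound 4, `CN1C[C@H](C(=O)NC2CCCC2)[C@@H](c2ccc(/C=C/C(=O)Nc3ccccc3N)cc2)C1`, has not yet been measured. It differs from compound 2 by cyclopentyl in place of 3-chlorophenyl on an amide-type nitrogen. For the measured compounds named here, every measured step so far exchanges one aryl group on that amide-type nitrogen for another aryl group, and none of those steps moved the number far. Going by the values given here, no measured step exchanges an aryl group for a non-aromatic ring, so the change to cyclopentyl has no direct precedent here. On that basis compound 4 is expected to stay close to compound 2, with a step of a 1.3-fold higher number from compound 2 to compound 4 (0.11 log units; within the scatter), and its estimated value in this assay is 9 mL/min/kg, with a range from 4 mL/min/kg to 20 mL/min/kg.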

Compound 4, clearance: 9 mL/min/kg
Compound 4: middle estimate and measured number agree at the digits printed; measured number inside the range.
By their numbers in this assay, from the lowest: compounds 2, 4, 1 and 3 (each within the scatter of the next, the first and the last beyond it).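

Compound 4 brings the first non-aromatic ring onto the amide-type nitrogen, and in this assay the exchange stays within the scatter against all three aryl partners (a 1.3-fold higher number from compound 2 to compound 4 (0.11 log units; within the scatter); a 1.1-fold lower number from compound 1 to compound 4 (0.05 log units; within the scatter); a 1.7-fold lower number from compound 3 to compound 4 (0.22 log units; within the scatter)). Among these four compounds, then, an aromatic ring at this position is not needed for a number in this range, and cyclopentyl cannot be told apart from any of the three aryl groups. Nothing available here bears on why the number holds across this change.

The compounds shown leave open whether a cyclopropyl ring, a ring carrying an amine or a carboxylic acid, or an open butyl chain on that nitrogen would stay as close. A single non-aromatic ring cannot show how far this result extends.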